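Trifluoromethylphenyl in Place of Bromophenyl on a Shared Core

The source may report more compounds than this note shows. Statements on the series, on what has been measured and on what is new or still open speak of the compounds shown alone.

Measured so far:
compound 1 `c1cn2cc(-c3ccsc3)nc(-c3ccc4ncn(C5CCCCC5)c4c3)c2n1` — 23.1%
compound 2 `Brc1ccc(-c2cn3ccnc3c(-c3ccc4ncn(C5CCCCC5)c4c3)n2)cc1` — 42.9%

In a functional assay on UO-31 cells (Homo sapiens) for inhibition, read by sulforhodamine B assay, with a stated time of 48 h, tested at 10 uM (on this read-out higher numbers stand for more inhibition at the one concentration tested (going by the name of the read-out) and lower numbers for less inhibition), compound 1 gives 23.1%, and in the same assay compound 2 gives 42.9%. Within the data shown here, compound 2 holds the higher of the two numbers known; the only measured step, a number 19.8 percentage points higher from compound 1 to compound 2 (beyond the scatter), lies beyond the scatter and replaced thiophen-3-yl with 4-bromophenyl.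

Compound 3 `FC(F)(F)c1cccc(-c2cn3ccnc3c(-c3ccc4ncn(C5CCCCC5)c4c3)n2)c1` is not yet measured. It differs from compound 2 as follows: 3-(trifluoromethyl)phenyl in place of 4-bromophenyl on an aromatic carbon. Among the measured compounds shown here, this change keeps a six-membered aromatic ring of carbon only and alters only the group on that ring, so the one measured step does not speak directly to it. The step from compound 2 to compound 3 is therefore expected to stay within the scatter, a number 2.9 percentage points lower from compound 2 to compound 3 (within the scatter). Compound 3 is estimated at 40%, with a range from 20% to 60%.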

Compound 3, a percentage reported as inhibition, at one concentration (the size of the read-out at that concentration, not a potency): 22.5%
Beside the measured number, compound 3's estimate is 17.5 percentage points above it; the measured number falls inside the stated range.
By their numbers in this assay, from the lowest: compounds 3 and 1 (each within the scatter of the next); then compound 2.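

In this assay, putting 3-(trifluoromethyl)phenyl in place of 4-bromophenyl gives a number 20.4 percentage points lower from compound 2 to compound 3 (beyond the scatter), so keeping a six-membered aromatic ring of carbon only at this position is not enough to hold the number of compound 2. Set against thiophen-3-yl, the same group gives a number 0.6 percentage points lower from compound 1 to compound 3 (within the scatter), which leaves 4-bromophenyl as the one group of the three that stands apart here. Nothing available explains this difference.

The 4-bromophenyl and 3-(trifluoromethyl)phenyl groups differ both in the group on the ring and in its numbered place, so the compounds shown cannot separate these two changes. From the compounds shown here alone, how this position would respond to a phenyl ring carrying an amine or a carboxylic acid also remains open.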